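Hydrazone side-chain variation on a nitrothienylthiazole series

The source may hold more compounds than are shown below. What is called first, only, known or untested is meant among the compounds shown, and "the series" means these compounds.

Measured compounds in an assay on isolated protein for inhibition of Amine oxidase [flavin-containing] B (Homo sapiens), read by fluorescence, with a stated time of 20 min; a lower number here means a stronger inhibitor, a higher number a weaker inhibitor:
- compound 1, `CC/C(C)=N\Nc1nc(-c2cccc([N+](=O)[O-])c2)cs1`: 351 nM
- compound 2, `CCC/C(CC)=N\Nc1nc(-c2cccc([N+](=O)[O-])c2)cs1`: 189 nM
- compound 3, `CCCC/C(CC)=N\Nc1nc(-c2cccc([N+](=O)[O-])c2)cs1`: 182 nM

The three numbers are bunched together. Compound 1 sits at one edge of the set, yet the step of a 1.9-fold lower number from compound 1 to compound 2 (0.27 log units; within the scatter) is within the scatter, and compound 3 is not further from compound 1 than compound 2 is. The chain on the hydrazone carbon is the only part that varies, and so far no change there has moved the number beyond the scatter: a 1.9-fold lower number from compound 1 to compound 2 (0.27 log units; within the scatter) and a 1.0-fold lower number from compound 2 to compound 3 (0.02 log units; within the scatter) were both flat.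

Compound 4, `C/C(=N/Nc1nc(-c2cccc([N+](=O)[O-])c2)cs1)C1CCCCC1`, has not yet been tested in this assay. Relative to compound 1 the change is cyclohexyl in place of ethyl on a carbon with a double bond to nitrogen. This places a ring where earlier compounds had only open chains, so the flat steps a 1.9-fold lower number from compound 1 to compound 2 (0.27 log units; within the scatter) and a 1.0-fold lower number from compound 2 to compound 3 (0.02 log units; within the scatter) bear on it only loosely; they suggest that growth at this position leaves the number roughly where it is. The expected step is a 1.4-fold lower number from compound 1 to compound 4 (0.13 log units; within the scatter), no more than the scatter. Compound 4 is therefore estimated at 260 nM, within 110 nM to 620 nM.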

Compound 4, half-maximal inhibitory concentration: 7.2 nM
Estimate against measurement, compound 4: 36-fold (1.56 log units) above, outside the stated range (below it).
By their numbers in this assay, from the lowest: compound 4; then compounds 3, 2 and 1 (each within the scatter of the next).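

In this assay the position on the carbon with a double bond to nitrogen proves far from flat: cyclohexyl in place of ethyl gives a 49-fold lower number from compound 1 to compound 4 (1.69 log units; beyond the scatter) and stands apart from the open-chain changes. Those changes, such as a 1.9-fold lower number from compound 1 to compound 2 (0.27 log units; within the scatter) and a 1.0-fold lower number from compound 2 to compound 3 (0.02 log units; within the scatter), stayed within the scatter, so this position responds strongly to at least one change even though open-chain growth left the number nearly unmoved. Nothing available bears on what lies behind the large step.

The compounds shown leave open whether the gain belongs to the ring or to the larger carbon count, which a straight hexyl chain at this position would help to separate. They also leave open how far the result extends to other rings, such as cyclopentyl, phenyl or piperidine.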